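The source may report more compounds than this note shows. Statements on the series, on what has been measured and on what is new or still open speak of the compounds shown alone.

Measured so far in a functional assay on the whole organism (strain Kunming) with Mus musculus as the target, with a stated time of 0.5 h, at a dose of 300 mg/kg by the intraperitoneal route; on this read-out higher numbers stand for a weaker effect at the one dose given and lower numbers for a stronger effect:
compound 1 `COc1ccccc1/C=C/C(=O)OC/C=C/c1cc(OC)c(OC)cc1OC` gives 50%
compound 2 `COc1cc(OC)c(OC)cc1/C=C/COC(=O)/C=C/c1cc(OC)c(OC)c(OC)c1OC` gives 0%

Compound 1 stands at the highest of the two numbers recorded; the nearest value is that of compound 2, which lies lower by a gap beyond the usual scatter. Going by the values given here, no single-change step between measured compounds is available, so nothing here shows how one substituent swap on the cinnamate ring moves this read-out.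

Compound 3 `COc1cc(OC)c(OC)cc1/C=C/COC(=O)/C=C/c1ccccc1Cl` is the unmeasured member. It differs from compound 1 by chloro in place of methoxy on an aromatic carbon.

Among the compounds with values here, with no measured step of this kind to lean on, the expectation for compound 3 in this assay is a step of no size beyond the scatter in either direction, which corresponds to a number 5 percentage points lower from compound 1 to compound 3 (within the scatter). On that basis compound 3 is estimated at 45%, within a wide range from 0% to 90%.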

Compound 3, a percentage reported as activity, at one dose (the size of the read-out at that dose, not a potency): 25%
Compound 3: the middle estimate sits 20 percentage points above what was measured, and the stated range covers the measured number.
By their numbers in this assay, from the lowest: compound 2; then compound 3; then compound 1.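

In this assay, going by these compounds alone, chloro in place of methoxy on an aromatic carbon, ortho to a large group, gives a number 25 percentage points lower from compound 1 to compound 3 (beyond the scatter), the first single-change step. On this read-out a lower number stands for a stronger effect at the one dose given, so this position is not silent: the change from 2-methoxyphenyl to 2-chlorophenyl moves the result, and here it moves towards a stronger effect. Nothing available accounts for this step.

A single step gives a direction for one swap at one place and no trend, and it leaves open how an amine, a carboxylic acid or a longer alkoxy chain would read at this position. From the compounds shown here alone, whether chloro gives a step of similar size on a differently substituted core also remains open.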